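The source may hold more compounds than are shown below. What is called first, only, known or untested is meant among the compounds shown, and "the series" means these compounds.

Compound 1, `CCCCCC[C@@H](O)C/C=C\CCCCCCCCSCCC(=O)NCc1ccc(O)c(OC)c1`, in an assay on HEK293 cells for antagonist activity at transient receptor potential cation channel subfamily V member 2 (Rattus norvegicus), read by fluorescence and calcium flux, with a stated time of 5 min; on this read-out higher numbers stand for weaker inhibition and lower numbers for stronger inhibition: > 10000 nM.
Compound 2, `CCCCCCCC/C=C\CCCCCCCCCCCC(=O)NCc1ccc(O)c(OC)c1`, in this assay: 490 nM.

The value of compound 1 is a limit of this assay, not a number, so compound 1 stands at the limit of > 10000 nM in this assay, at which 1 of the 2 values shown sits. Compound 2, which carries a long chain without a hydroxyl, gives 490 nM in this assay. Compound 3, `CCCCCCCCCCCCCCCCSCCC(=O)NCc1ccc(O)c(OC)c1`, differs from compound 1 by octyl in place of 4-hydroxydec-1-en-1-yl on a saturated chain carbon, eight bonds along the chain from a sulfur. For the measured compounds named here, no measured pair covers this change, so the size of the step is an expectation: the step is expected to run toward stronger inhibition, an at least 4.0-fold lower number from compound 1 to compound 3 (0.60 log units; beyond the scatter). Compound 3 is therefore estimated at 2500 nM, likely between 500 nM and 10000 nM.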

Compound 3, half-maximal inhibitory concentration: 3800 nM
Compound 3: the middle estimate sits 1.5-fold (0.18 log units) below what was measured; measured number inside the range.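

Putting octyl in place of 4-hydroxydec-1-en-1-yl gives an at least 2.6-fold lower number from compound 1 to compound 3 (0.42 log units; beyond the scatter). Compound 3 thus shows that a chain with the sulfur can still give a measured number in this assay. The step has only a lower bound, since the value of compound 1 is a limit of the assay and not a number: the limit of > 10000 nM in this assay, at which 1 of the 3 values shown sits.

Going by these compounds, the change removes a hydroxyl, a double bond and a stereocentre and shortens the group all at once, so which of these matters stays open. Also open, on these data alone, is how an amine or a longer chain would read in this place.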